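Adding a bromine to compound 2 and its expected cytotoxicity

The source may hold more compounds than are shown below. What is called first, only, known or untested is meant among the compounds shown, and "the series" means these compounds.

Compound 1 `Cc1nc(S)n(Nc2ccc(Cl)cc2)c1-c1ccccc1` is measured in a functional assay on MT4 cells (Homo sapiens) for cytotoxicity (on this read-out higher numbers stand for lower toxicity in this test and lower numbers for higher toxicity in this test), at 134000 nM. Its relative compound 2 `Cc1nc(S)n(Nc2cccc(Cl)c2)c1-c1ccccc1` gives 66700 nM in this assay, and the change between them, a 2.0-fold lower number from compound 1 to compound 2 (0.30 log units; within the scatter), shows the two within the scatter of one another. Compound 3 `Cc1cccc(NN2C(S)=NC(C)C2C)c1` gives 360000 nM in this assay, a higher number than compound 2 by more than the scatter. Compound 4 `Cc1nc(S)n(Nc2cccc(Cl)c2)c1-c1ccc(Br)cc1` differs from compound 2 by bromo in place of hydrogen on an aromatic carbon. No measured step here adds a halogen to the phenyl group, so the only step shown, from compound 1 to compound 2, bears on it just by indicating how small such single changes have been. No step beyond the scatter is expected in this assay: for compound 4 the expected step is a 1.3-fold lower number from compound 2 to compound 4 (0.13 log units; within the scatter). Compound 4 is therefore estimated at 50000 nM, with a range from 20000 nM to 130000 nM.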

Compound 4, half-maximal cytotoxic concentration: 33200 nM
For compound 4 the middle estimate is 1.5-fold (0.18 log units) above the measured one; low and high end bracket the measured number.
By their numbers in this assay, from the lowest: compounds 4, 2 and 1 (each within the scatter of the next, the first and the last beyond it); then compound 3.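

Changing phenyl to 4-bromophenyl gives, in this assay, a 2.0-fold lower number from compound 2 to compound 4 (0.30 log units; within the scatter). The earlier step concerned only where the chlorine sits on the other aromatic ring, whereas this one shows that a bromine can be added to the phenyl group, para to a large group, without a change beyond the scatter. No available evidence explains this result.

Still open, going by these compounds, is whether a larger change at this place, such as an amine or a carboxylic acid, would move the number beyond the scatter.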